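A few compounds are considered here, and "the series" means these few. Any claim that something is new, unique, unknown or untested is made for them only; others in the source may bear on it.

Compound 1, `O=C(Nc1ccccc1C(F)(F)F)C1CCc2ccccc2N1C(=O)c1ccccc1`: 8090 nM in a functional assay on ACHN cells (Homo sapiens) for cytotoxicity, read by sulforhodamine B assay, with a stated time of 72 h; a lower number here means a stronger inhibitor of growth, a higher number a weaker inhibitor of growth.
Compound 2, `O=C(Nc1ccccc1O)C1CCc2ccccc2N1C(=O)c1ccccc1`: 4260 nM in this assay.

Compound 1 gives the higher of the two numbers, though the step of a 1.9-fold lower number from compound 1 to compound 2 (0.28 log units; within the scatter) lies within the scatter. Compound 3, `CCC(=O)N1c2ccccc2CCC1C(=O)Nc1ccccc1C(F)(F)F`, differs from compound 1 at another place: ethyl in place of phenyl on a carbonyl carbon. For the measured compounds named here, the only measured step changes a group on the aromatic ring, not the group on the carbonyl carbon, so no measured step bears directly on this change. With nothing to point either way, the step of a 1.0-fold lower number from compound 1 to compound 3 (0.00 log units; within the scatter) is expected to stay within the scatter. Compound 3 is estimated at 8000 nM, with a range from 2500 nM to 25000 nM.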

Compound 3, concentration for 50% growth inhibition: > 80000 nM
Compound 3 was reported as a limit; the forecaster's own chance of this, stated with the estimate: 10%; at least 10-fold (1.00 log units) between middle value and limit.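

Benzoyl on the ring nitrogen turns out to matter in a way the aromatic-ring change did not: replacing its phenyl with ethyl gives an at least 9.8-fold higher number from compound 1 to compound 3 (0.99 log units; beyond the scatter), whereas a 1.9-fold lower number from compound 1 to compound 2 (0.28 log units; within the scatter). This is one pair, so it shows only that this place on the core of compound 1 tolerates this change poorly. The value of compound 3 is a limit, not a number: the limit of > 80000 nM in this assay, at which 1 of the 3 values shown sits.

From the compounds shown here alone, whether a cyclohexyl group or a longer chain such as butyl on this carbonyl carbon would keep the growth inhibition of compound 1 remains open. So does whether ethyl would act the same way in compound 2, which carries hydroxy.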